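Compound 4: a trifluoromethyl change to compound 3

The source may report more compounds than this note shows. Statements on the series, on what has been measured and on what is new or still open speak of the compounds shown alone.

Measured so far in an ADME assay on cells (Rhabdomyosarcoma cell, Homo sapiens) for cytotoxicity, read by MTT assay, with a stated time of 72 h; on this read-out higher numbers stand for lower toxicity in this test and lower numbers for higher toxicity in this test:
- Compound 1 `Nc1sc2c(c1-c1nc3ccccc3s1)CCCC2`: 253 ug/mL
- Compound 2 `Fc1ccccc1/C=N/c1sc2c(c1-c1nc3ccccc3s1)CCC2`: 270 ug/mL
- Compound 3 `Fc1ccccc1/C=N/c1sc2c(c1-c1nc3ccccc3s1)CCCC2`: 319 ug/mL

The three measured compounds form a tight group. Compound 3 gives 319 ug/mL, and this lies within the usual scatter of both other values, so it cannot be ranked above them with any confidence.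

The next compound is compound 4 `FC(F)(F)c1ccc(/C=N/c2sc3c(c2-c2nc4ccccc4s2)CCCC3)cc1`, which keeps the core of compound 3 and alters one group: 4-(trifluoromethyl)phenyl in place of 2-fluorophenyl on a carbon with a double bond to nitrogen. In words, 4-(trifluoromethyl)phenyl stands in place of 2-fluorophenyl on a carbon with a double bond to nitrogen.

Going by the values given here, one measured step bears on this change: a 1.3-fold higher number from compound 1 to compound 3 (0.10 log units; within the scatter). That is a large structural change at the same part of the molecule, yet it stayed within the scatter. Among the compounds with values here, no measured pair shows what changing the groups on this benzene ring does in this assay, so this evidence is indirect. A smaller edit is therefore expected to leave the number about where it is, with no clear direction. The expected step is a 1.1-fold lower number from compound 3 to compound 4 (0.03 log units; within the scatter), which means no move beyond the scatter is anticipated. Compound 4 is estimated at 300 ug/mL, with an expected range from 170 ug/mL to 520 ug/mL.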

Compound 4, half-maximal cytotoxic concentration: 250 ug/mL
Compound 4: middle estimate off by 1.2-fold (0.08 log units), on the high side; the measured number falls inside the stated range.
By their numbers in this assay, from the lowest: compounds 4, 1, 2 and 3 (each within the scatter of the next).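

Going by these compounds alone, this is the first pair that changes only the substituents on the benzene ring, while keeping the ring itself on the carbon with a double bond to nitrogen. In this assay, putting 4-(trifluoromethyl)phenyl in place of 2-fluorophenyl gives a 1.3-fold lower number from compound 3 to compound 4 (0.11 log units; within the scatter), so this swap to a group with more heavy atoms and more fluorine does not shift the read-out measurably. The step cannot be assigned to the kind of group or to where it sits on the ring, since both differ between the two compounds, and nothing available here offers an explanation for the result.

The compounds shown leave open whether any change at this position can move the number beyond the scatter, since every group on the benzene ring here carries only carbon and fluorine. A carboxylic acid or an amine on that ring, or a longer chain in place of the ring, would test whether this tight grouping holds for groups built from other atoms.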